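Propyl to 3-chlorophenyl on the fused core: expected cytotoxicity

The source may report more compounds than this note shows. Statements on the series, on what has been measured and on what is new or still open speak of the compounds shown alone.

Working notes on a small series sharing one fused core. Compound 1 `O=C(Nn1c(-c2cccc([N+](=O)[O-])c2)nc2c(CCc3ccccc3)n[nH]c2c1=O)c1cccnc1` gives 20.1% in a functional assay on HT-29 cells (Homo sapiens) for cytotoxicity, read by sulforhodamine B assay, with a stated time of 2 days, tested at 100 uM; on this read-out higher numbers stand for more inhibition at the one concentration tested (going by the name of the read-out) and lower numbers for less inhibition. Compound 2 `CCCc1n[nH]c2c(=O)n(NC(=O)c3ccccc3)c(-c3cccc([N+](=O)[O-])c3)nc12` gives 18.7% in this assay, a number within the scatter of that of compound 1, so the two cannot be told apart. Going by the values given here, compound 3 `CCCc1n[nH]c2c(=O)n(NC(=O)c3ccccc3)c(-c3cccc(OC)c3)nc12` gives 6.27% in this assay, and the step of a number 12.4 percentage points lower from compound 2 to compound 3 (beyond the scatter) is the only single-point change measured so far; it concerns the group on the aromatic carbon of the six-membered ring and not the five-membered ring.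

The step under consideration goes from compound 2 to compound 4 `O=C(Nn1c(-c2cccc([N+](=O)[O-])c2)nc2c(-c3cccc(Cl)c3)n[nH]c2c1=O)c1ccccc1`: 3-chlorophenyl in place of propyl on an aromatic carbon. Among the compounds with values here, no measured step touches the place on the five-membered ring where the propyl sits, and the difference between compound 1 and compound 2 involves two places at once and lies within the scatter. There is therefore no measured guide for this change, and with no ground for either direction the expectation is of a step not beyond the scatter, a number 3.3 percentage points higher from compound 2 to compound 4 (within the scatter).

For compound 4 the estimate in this assay is 22%, with a range from 5% to 45%.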

Compound 4, a percentage reported as inhibition, at one concentration (the size of the read-out at that concentration, not a potency): 89.8%
Compound 4: middle estimate off by 67.8 percentage points, on the low side, outside the stated range (above it).
By their numbers in this assay, from the lowest: compound 3; then compounds 2 and 1 (each within the scatter of the next); then compound 4.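

Going by these compounds alone, this is the first measured step at this place on the five-membered ring, and it shows that the place is far from indifferent to the group it carries: in this assay, 3-chlorophenyl in place of propyl gives a number 71.1 percentage points higher from compound 2 to compound 4 (beyond the scatter). The other single-place change in the series, methoxy in place of nitro, gives a number 12.4 percentage points lower from compound 2 to compound 3 (beyond the scatter), which is beyond the scatter but modest, so among the steps measured so far, the change at the five-membered ring is by far the larger. Compound 2 and compound 4 differ in this one place only, so the step belongs to this exchange, but nothing at hand gives a reason for its size.

The compounds shown leave open whether the step comes from the aromatic ring itself or from its chlorine, a question that plain phenyl on the same carbon would address, while a longer chain such as hexyl would show whether an open chain of more atoms can do the same. They also leave open whether methoxy in place of nitro lowers the number as it does from compound 2 to compound 3 when 3-chlorophenyl occupies this place.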